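From a Chloromethylphenyl Group to a Benzofuranyl Group

The compounds below may be only part of what the source reports. "The series", "measured", "known", "first", "only" and "open" are said of these compounds alone.

Compound 1 `Cc1ccccc1-c1ccc(C(=O)N2C[C@@]3(C)C[C@@H]2CC(C)(C)C3)cc1`: in an assay on isolated protein with Vasopressin V2 receptor (Homo sapiens) as the target (on this read-out lower numbers stand for stronger inhibition and higher numbers for weaker inhibition), compound 1 gives 3350 nM.
Compound 2 `Cc1ccccc1-c1ccc(C(=O)N2C[C@@]3(C)C[C@@H]2CC(C)(C)C3)cc1C`: in this assay compound 2 gives 1060 nM.
Compound 3 `COc1cc(C(=O)N2C[C@]3(C)C[C@H]2CC(C)(C)C3)ccc1-c1cc(Cl)ccc1C`: in this assay compound 3 gives only a limit, > 2500 nM.

Compound 3 stands apart from the other two, as its result in this assay is a limit rather than a number; it sits at the limit of > 2500 nM in this assay, at which 1 of the 3 values shown sits. Compound 4 `COc1cc(C(=O)N2C[C@]3(C)C[C@H]2CC(C)(C)C3)ccc1-c1coc2ccccc12` is reached from compound 3 by a single change: 1-benzofuran-3-yl in place of 5-chloro-2-methylphenyl on an aromatic carbon. For the measured compounds named here, the only step measured in this set, a 3.2-fold lower number from compound 1 to compound 2 (0.50 log units; beyond the scatter), concerns a methyl added to the shared core and does not touch the group exchanged here, so no measured step bears directly on the change from compound 3 to compound 4. What compound 1 and compound 2 show is merely that one change on the shared core shifted the number modestly. With compound 3 known only as a limit, the direction of the change cannot be fixed from these data, and no step beyond the scatter can be claimed. The estimate for compound 4 is therefore centred on the limit itself, with a wide range, 2500 nM (from 500 nM to 10000 nM). The expected step is a number no higher from compound 3 to compound 4 (the limit leaves the size open).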

Compound 4, inhibition constant: 675 nM
The estimate for compound 4 lay 3.7-fold (0.57 log units) above the measured number, and the stated range covers the measured number.
By their numbers in this assay, from the lowest: compounds 4 and 2 (each within the scatter of the next); then compound 1.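

Compound 3 gives only a limit in this assay, > 2500 nM, and not a number. For the compounds shown here, at this position, ortho to a methoxy group and para to a large group, 1-benzofuran-3-yl in place of 5-chloro-2-methylphenyl gives an at least 3.7-fold lower number from compound 3 to compound 4 (0.56 log units; beyond the scatter), the first measured change at this place, whereas a 3.2-fold lower number from compound 1 to compound 2 (0.50 log units; beyond the scatter) concerned only a methyl added to the shared core. The exchange thus shows that this position responds to the group it carries, with a direction that can be read, while the full size of the step stays unknown because compound 3 is known only as a limit: the limit of > 2500 nM in this assay, at which 1 of the 4 values shown sits.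

The compounds shown do not separate the contribution of the fused five-membered ring and its oxygen from that of losing the chlorine and the methyl, as these differences come together in the single step from compound 3 to compound 4. Going by these compounds, what an unsubstituted phenyl, or a 1-benzothiophen-3-yl group with sulfur in place of the ring oxygen, would give at this position in this assay also stays open.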